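The compounds below may be only part of what the source reports. "The series", "measured", "known", "first", "only" and "open" are said of these compounds alone.

Three compounds have been measured in an in vitro functional assay on CHO/Galpha16 cells for antagonist activity at C-C chemokine receptor type 8 (Homo sapiens), read by FLIPR; a lower number here means a stronger inhibitor, a higher number a weaker inhibitor:

Compound 1, `CCCC(=O)N1CCC(NS(=O)(=O)c2ccc(NC(=O)c3ccccc3)c3ccccc23)CC1`, gives 12.5 nM.
Compound 2, `CCCC(=O)N1CCC(NS(=O)(=O)c2ccc(NC(=O)CC3CCCC3)c3ccccc23)CC1`, gives 145 nM.
Compound 3, `CCCC(=O)N1CCC(NS(=O)(=O)c2ccc(NC(=O)C3CCCCC3)c3ccccc23)CC1`, gives 6.1 nM.

Compound 3 stands lowest of the three numbers: a 2.0-fold lower number from compound 1 to compound 3 (0.31 log units; beyond the scatter) and a 24-fold lower number from compound 2 to compound 3 (1.38 log units; beyond the scatter) both lead down to it. Compound 4, `CCCC(=O)N1CCC(NS(=O)(=O)c2ccc(NC(=O)c3cccc(C)c3)c3ccccc23)CC1`, differs from compound 3 by 3-methylphenyl in place of cyclohexyl on a carbonyl carbon. Going by the values given here, the only measured step that speaks to this change is a 2.0-fold lower number from compound 1 to compound 3 (0.31 log units; beyond the scatter), which runs in the opposite direction, from an aromatic ring to cyclohexyl; the methyl on the entering ring has no counterpart among the measured compounds. Returning to an aromatic ring is therefore expected to undo that gain, giving compound 4 a modestly higher number in this assay, a 1.8-fold higher number from compound 3 to compound 4 (0.26 log units; within the scatter). The estimate for compound 4 is 11 nM, with a range from 4 nM to 30 nM.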

Compound 4, half-maximal inhibitory concentration: 5.1 nM
Estimate against measurement, compound 4: 2.2-fold (0.33 log units) above; low and high end bracket the measured number.
By their numbers in this assay, from the lowest: compounds 4 and 3 (each within the scatter of the next); then compound 1; then compound 2.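

In this assay an aromatic ring on a carbonyl carbon can match cyclohexyl once it carries a methyl, the step being a 1.2-fold lower number from compound 3 to compound 4 (0.08 log units; within the scatter) and so no separation of the two groups. Methyl in place of hydrogen on an aromatic carbon is a real if modest change, with a 2.5-fold lower number from compound 1 to compound 4 (0.39 log units; beyond the scatter) on record for it, while a 28-fold lower number from compound 2 to compound 4 (1.45 log units; beyond the scatter) leaves cyclopentylmethyl as the one clearly weaker group of the four. No measured evidence accounts for these steps. Going by these compounds, whether an amine or a carboxylic acid in place of that methyl would hold the number at this level stays open.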